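Acylating the Amino Group of Compound 2

The compounds below may be only part of what the source reports. "The series", "measured", "known", "first", "only" and "open" are said of these compounds alone.

In a functional assay on HT-29 cells (Homo sapiens) for inhibition, read by MTT assay (a lower number here means a stronger inhibitor, a higher number a weaker inhibitor), compound 2 (`N#Cc1c(N)sc(C(=O)Nc2ccccc2)c1-c1ccccc1`) gives 8390 nM and stands level with compound 3 (`CCOC(=O)c1c(N)sc(C(=O)Nc2ccccc2)c1-c1ccccc1`) at 7490 nM while compound 1 (`N#CCC(=O)Nc1sc(C(=O)Nc2ccc(Cl)cc2)c(-c2ccccc2)c1C#N`) lies well lower at 860 nM on the same scale. Compound 4 (`N#CCC(=O)Nc1sc(C(=O)Nc2ccccc2)c(-c2ccccc2)c1C#N`) differs from compound 2 by one change ((cyanomethyl)carbonyl in place of hydrogen on a nitrogen on an aromatic ring), amino to ((cyanomethyl)carbonyl)amino. Among the measured compounds shown here, the only measured step (a 1.1-fold lower number from compound 2 to compound 3 (0.05 log units; within the scatter)) lies within the scatter and concerns another place, so it offers little guidance. Compound 1 carries the same (cyanomethyl)carbonyl group plus a chloro group absent from compound 4, which makes it the nearest guide. The estimated step (a 5.6-fold lower number from compound 2 to compound 4 (0.75 log units; beyond the scatter)) is therefore expected to go toward a lower number, short of compound 1. Compound 4 is expected at 1500 nM (estimated range 600 nM to 4500 nM).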

Compound 4, half-maximal inhibitory concentration: 6590 nM
Estimate against measurement, compound 4: 4.4-fold (0.64 log units) below, and the stated range ends below it.
By their numbers in this assay, from the lowest: compound 1; then compounds 4, 3 and 2 (each within the scatter of the next).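

Putting (cyanomethyl)carbonyl on the nitrogen on the aromatic ring leaves the number in this assay essentially unchanged (a 1.3-fold lower number from compound 2 to compound 4 (0.10 log units; within the scatter)), so acylation alone does not account for the low value of compound 1. The gap instead follows the chloro group, whose removal gives a clear step (a 7.7-fold higher number from compound 1 to compound 4 (0.88 log units; beyond the scatter)). Nothing available explains why this single substituent matters here.

The compounds shown leave open whether a fluoro or methoxy group in place of chloro would give a similar step. As far as these compounds go, it also remains open whether chloro would do the same with the free amino group of compound 2.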